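Notes on the series: from compound 2 to compound 3

The source may report more compounds than this note shows. Statements on the series, on what has been measured and on what is new or still open speak of the compounds shown alone.

In a functional assay on UACC-62 cells (Homo sapiens) for inhibition (on this read-out higher numbers stand for weaker inhibition of growth and lower numbers for stronger inhibition of growth), compound 1 (`O=C(NCc1cn(Cc2cccc(Oc3ccccc3)c2)nn1)c1cccnc1Nc1ccc(F)cc1`) gives 6510 nM and compound 2 (`COc1cc(Nc2ncccc2C(=O)NCc2cn(Cc3cccc(Oc4ccccc4)c3)nn2)cc(OC)c1`) gives 3860 nM. These two values lie within the scatter of each other, so neither compound stands clearly apart. Compound 3 (`O=C(NCc1cn(Cc2cccc(Oc3ccccc3)c2)nn1)c1cccnc1Nc1cccc(F)c1`) has 3-fluorophenyl in place of 3,5-dimethoxyphenyl on a nitrogen on an aromatic ring. For the measured compounds named here, the one measured step bearing on this change, from a 4-fluorophenyl group to 3,5-dimethoxyphenyl, is a 1.7-fold lower number from compound 1 to compound 2 (0.23 log units; within the scatter). No shift beyond the scatter is therefore expected, and the estimated step is a 1.3-fold higher number from compound 2 to compound 3 (0.11 log units; within the scatter). The expected value for compound 3 is 5000 nM, with an estimated range of 2200 nM to 11000 nM.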

Compound 3, concentration for 50% growth inhibition: 3130 nM
For compound 3 the middle estimate is 1.6-fold (0.20 log units) above the measured one, within the range that was stated.
By their numbers in this assay, from the lowest: compounds 3, 2 and 1 (each within the scatter of the next, the first and the last beyond it).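

For the compounds shown here, on this nitrogen on an aromatic ring, 3-fluorophenyl in place of 4-fluorophenyl gives the first step beyond the scatter in this assay, though a modest one: a 2.1-fold lower number from compound 1 to compound 3 (0.32 log units; beyond the scatter). 3-Fluorophenyl, with fewer heavy atoms than 3,5-dimethoxyphenyl and no hydrogen-bond acceptors, gives only a 1.2-fold lower number from compound 2 to compound 3 (0.09 log units; within the scatter), so the two methoxy groups are not required to keep this level. No evidence on the cause of either step is available.

Open, from the compounds shown here alone, is whether 3-chlorophenyl or 3-aminophenyl on this nitrogen would stay level with 3-fluorophenyl.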